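Trifluoromethoxy for Trifluoromethyl on a Shared Urea Core

The compounds below may be only part of what the source reports. "The series", "measured", "known", "first", "only" and "open" are said of these compounds alone.

Of the compounds shown here, three have been measured in a physicochemical assay for lipophilicity, read by HPLC, with a stated time of 90 min, tested at 100 uM; on this read-out higher numbers stand for higher lipophilicity and lower numbers for lower lipophilicity. Compound 2 `O=C(Nc1ccc(C(F)(F)F)cc1)NC1CCN(C(=O)[C@@H]2CCOC2)CC1` gives 3.27. Compound 1 `O=C(Nc1ccc(OC(F)(F)F)cc1)NC1CCN(C(=O)[C@@H]2CCOC2)CC1` differs from it by one change, (trifluoromethoxy in place of trifluoromethyl on an aromatic carbon), and gives 3.38, so that a number 0.11 log units higher from compound 2 to compound 1 (within the scatter). Compound 3 `O=C(Nc1ccc(C(F)(F)F)cc1)NC1CCN(C(=O)C2=COCC2)CC1` carries a different core, and the two cores differ as a group of 5 heavy atoms (4 carbon, 1 oxygen; one five-membered non-aromatic ring with 1 hetero atom) in place of a group of 5 heavy atoms (4 carbon, 1 oxygen; one five-membered non-aromatic ring with 1 hetero atom), on a carbonyl carbon; in this assay compound 3 gives 3.37, which means a number 0.10 log units higher from compound 2 to compound 3 (within the scatter).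

Compound 4 `O=C(Nc1ccc(OC(F)(F)F)cc1)NC1CCN(C(=O)C2=COCC2)CC1` has not yet been measured. It differs from compound 3 by trifluoromethoxy in place of trifluoromethyl on an aromatic carbon. This is the same change that leads from compound 2 to compound 1, made on the same kind of place, so the earlier step offers the best guide to what to expect. The step from compound 3 to compound 4 is estimated as a number 0.11 log units higher from compound 3 to compound 4 (within the scatter) because a number 0.11 log units higher from compound 2 to compound 1 (within the scatter) shows that this swap moved the reading by only a small amount. Compound 4 is therefore expected to give 3.48, with a likely range from 3.2 to 3.76.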

Compound 4, partition coefficient: 3.49
Compound 4: middle estimate off by 0.01 log units, on the low side; low and high end bracket the measured number.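

In this assay, putting trifluoromethoxy in place of trifluoromethyl gave a number 0.12 log units higher from compound 3 to compound 4 (within the scatter), a close match to a number 0.11 log units higher from compound 2 to compound 1 (within the scatter) seen on the other core, and the core change gave a number 0.11 log units higher from compound 1 to compound 4 (within the scatter), a close match to a number 0.10 log units higher from compound 2 to compound 3 (within the scatter). In these four compounds, then, the swap carried from one core to the other with a step of about the same small size. All four steps lie within the scatter, however, so they do not show that either change truly moves the reading, and no measured evidence here explains the result.

The compounds shown cover only two cores and only two groups on the aromatic carbon, so a third core could still behave differently. From the compounds shown here alone, it also remains open whether the same agreement between cores would appear with a larger step, for example with an amine or a carboxylic acid on that carbon.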